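Ring-nitrogen substituent and the outlook for compound 4

The source may report more compounds than this note shows. Statements on the series, on what has been measured and on what is new or still open speak of the compounds shown alone.

Compound 3 `Cc1cccc2sc(NC(=O)CCN3CCN(C4CCN(C)CC4)CC3)nc12` gives 6000 nM in an assay on membranes from brain for displacement of a labelled ligand from Sigma non-opioid intracellular receptor 1 (Cavia porcellus), read by scintillation counting, with a stated time of 120 min (on this read-out higher numbers stand for weaker inhibition and lower numbers for stronger inhibition), the highest number among the three measured compounds. In this assay compound 1 `Cc1cccc2sc(NC(=O)CCN3CCN(CCN(C)C)CC3)nc12` gives 1000 nM and compound 2 `Cc1cccc2sc(NC(=O)CCN3CCN(C4CCCCC4)CC3)nc12` gives 24 nM. The step of a 6.0-fold higher number from compound 1 to compound 3 (0.78 log units; beyond the scatter) is modest, the step of a 250-fold higher number from compound 2 to compound 3 (2.40 log units; beyond the scatter) is large, and the step of a 42-fold lower number from compound 1 to compound 2 (1.62 log units; beyond the scatter) is large; compound 2, with cyclohexyl on the ring nitrogen, stands lowest.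

Compound 4 `Cc1cccc2sc(NC(=O)CCN3CCN(CCN(C(C)C)C(C)C)CC3)nc12` is not yet measured. Its change from compound 3 is 2-(diisopropylamino)ethyl in place of 1-methylpiperidin-4-yl on an amine nitrogen in a ring. The measured step that bears on it is a 6.0-fold higher number from compound 1 to compound 3 (0.78 log units; beyond the scatter), read in reverse: compound 1 carries 2-(dimethylamino)ethyl, also an open chain ending in an amine, at the same ring nitrogen, and going from that chain to 1-methylpiperidin-4-yl raised the number modestly. Within the data shown here, no measured compound tells how the two isopropyl groups of the entering chain, in place of two methyl groups, shift the number, so the estimate rests on compound 1 with a wide range.

A modest decrease from compound 3 is therefore expected for compound 4, to an estimated 500 nM, with a range of 100 nM to 2500 nM. The expected step is a 12-fold lower number from compound 3 to compound 4 (1.08 log units; beyond the scatter).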

Compound 4, inhibition constant: 809 nM
Estimate against measurement, compound 4: 1.6-fold (0.21 log units) below; the range from low to high includes it.
By their numbers in this assay, from the lowest: compound 2; then compounds 4 and 1 (each within the scatter of the next); then compound 3.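

In this assay, the step of a 1.2-fold lower number from compound 1 to compound 4 (0.09 log units; within the scatter) shows that diisopropylamino in place of dimethylamino on the chain leaves compound 1 and compound 4 indistinguishable, so the two isopropyl groups, the open question for this chain, make no difference that this read-out can resolve. The 2-(diisopropylamino)ethyl group nevertheless stays well apart from both ring substituents on the amine nitrogen in a ring, with a 7.4-fold lower number from compound 3 to compound 4 (0.87 log units; beyond the scatter) and a 34-fold higher number from compound 2 to compound 4 (1.53 log units; beyond the scatter). Across the four compounds, only compound 2 carries a substituent with no nitrogen, and it has the lowest number at 24 nM; no listed compound goes against this link, though compound 2 is a single case and its cyclohexyl group also differs from the chains in being a ring.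

As far as these compounds go, it remains open whether a hexyl chain, which has no nitrogen and no ring, would stay near compound 2, or whether a longer chain ending in diisopropylamino would stay near compound 4. A phenyl ring in place of cyclohexyl is equally untested by the compounds shown, and nothing available explains any of these steps.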